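The source may report more compounds than this note shows. Statements on the series, on what has been measured and on what is new or still open speak of the compounds shown alone.

Compound 2, `CCC(=O)N[C@@H]1CCCc2c1cncc2N1Cc2cc(Cl)ccc2C1=O`, gives 5210 nM in an ADME assay on cells for inhibition of cytochrome P450 11B1, mitochondrial (Homo sapiens), read by HTRF (a higher number here means a weaker inhibitor, a lower number a stronger inhibitor), the higher of the two numbers measured here; its nearest neighbour is compound 1, `CCC(=O)N[C@@H]1CCCc2c1cncc2N1C(=O)c2ccc(Cl)cc2[C@@H]1C`, which in this assay gives 414 nM. The change to compound 3, `CCC(=O)N[C@@H]1CCCc2c1cncc2N1C(=O)c2ccc(Cl)cc2[C@H]1C`, is methyl in place of hydrogen on a saturated ring carbon. Within the data shown here, the only step that bears on it is the reverse one, a 13-fold higher number from compound 1 to compound 2 (1.10 log units; beyond the scatter), though compound 3 carries the methyl in the other configuration, so that step is a guide of uncertain weight. A step of moderate size toward a lower number is therefore expected, a 3.5-fold lower number from compound 2 to compound 3 (0.54 log units; beyond the scatter). Compound 3 is estimated at 1500 nM, in the range 400 nM to 5500 nM.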

Compound 3, half-maximal inhibitory concentration: 9410 nM
The estimate for compound 3 lay 6.3-fold (0.80 log units) below the measured number; measured number outside the range, above it.
By their numbers in this assay, from the lowest: compound 1; then compounds 2 and 3 (each within the scatter of the next).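

In this assay, methyl on this saturated ring carbon does not separate the compounds on its own: the step is a 1.8-fold higher number from compound 2 to compound 3 (0.26 log units; within the scatter). Among these compounds, the configuration at that carbon does, with a 23-fold higher number from compound 1 to compound 3 (1.36 log units; beyond the scatter), which the earlier compounds could not show, as they included only one methyl configuration. This large step comes with no change in atoms or bonds: the fact that compounds 1 and 3 differ only in the configuration as drawn

From the compounds shown here alone, whether an ethyl or a hydroxyl group at this carbon would show the same split between its two configurations remains open. So does whether the split would persist with a longer chain in place of the propanamide.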